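Methylated amide variant of compound 1

This account rests on a few compounds, and the source may have more. Where it says the series, first, only, none or still open, it means among the compounds named here.

Compound 1 `CS(=O)(=O)c1ccc(C(=O)NCC(=O)N(Cc2ccccc2)Cc2ccccc2)cc1[N+](=O)[O-]` gives > 60000 nM in an assay on isolated protein for inhibition of vitamin D3 receptor (Homo sapiens), read by fluorescence polarization (on this read-out lower numbers stand for stronger inhibition and higher numbers for weaker inhibition), which is a limit of the assay and not a number. Compound 2 `CN(Cc1cccc(F)c1)C(=O)CN(C)C(=O)c1ccc(S(C)(=O)=O)c([N+](=O)[O-])c1` gives > 60000 nM in this assay, again a limit. Compound 3 `CN(CC(=O)N1CCN(c2ccc(F)cc2)CC1)C(=O)c1ccc(S(C)(=O)=O)c([N+](=O)[O-])c1` gives > 60000 nM in this assay, also a limit.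

Compound 1 therefore stands where every value of the series stands: the limit of > 60000 nM in this assay, at which 3 of the 3 values shown sit. Going by the values given here, no order among the three can be read from this, and no step between measured numbers is available.

Compound 4 `CN(CC(=O)N(Cc1ccccc1)Cc1ccccc1)C(=O)c1ccc(S(C)(=O)=O)c([N+](=O)[O-])c1` differs from compound 1 by methyl in place of hydrogen on an amide-type nitrogen. Compound 2 and compound 3 already carry a methyl on an amide-type nitrogen and sit at the limit, so no step beyond the scatter is expected in this assay. Compound 4 is expected to give 60000 nM, with a range from 25000 nM to 200000 nM. The expected step is a number no higher from compound 1 to compound 4 (the limit leaves the size open).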

Compound 4, half-maximal inhibitory concentration: > 60000 nM
Compound 4 ended at the assay's limit (the forecaster's own chance of this, stated with the estimate: 85%); the middle value sits exactly at the limit.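

Compound 1 and compound 4 both sit at a limit and not at a number, so no step can be read between them: the limit of > 60000 nM in this assay, at which 4 of the 4 values shown sit.

The compounds shown leave open whether methyl in place of hydrogen on an amide-type nitrogen changes inhibition at all.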